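This account rests on a few compounds, and the source may have more. Where it says the series, first, only, none or still open, it means among the compounds named here.

Compound 1 `CS(=O)(=O)Nc1ccc(C/N=C(\S)NCc2ccccc2)cc1F` gives 9700 nM in an assay for inhibition of transient receptor potential cation channel subfamily V member 1 (Rattus norvegicus), with a stated time of 10 min; a higher number here means a weaker inhibitor, a lower number a stronger inhibitor.
Compound 2 `CCc1ccc(C/N=C(\S)NCc2ccc(NS(C)(=O)=O)c(F)c2)cc1` gives 1100 nM in this assay.

Of these two numbers, compound 2 holds the lower one, and compound 1 lies well above it, a gap beyond the scatter. Compound 3 `CC(C)c1ccc(C/N=C(\S)NCc2ccc(NS(C)(=O)=O)c(F)c2)cc1` differs from compound 2 by methyl in place of hydrogen on a saturated chain carbon bound to an aromatic carbon and a saturated chain carbon. No step of this kind has been measured among these compounds, so its direction cannot be read from them; a change of this size is expected to move this assay little, if at all, beyond the scatter. Compound 3 is therefore estimated at 800 nM, within 300 nM to 2500 nM. The expected step is a 1.4-fold lower number from compound 2 to compound 3 (0.14 log units; within the scatter).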

Compound 3, half-maximal inhibitory concentration: 520 nM
Compound 3: middle estimate off by 1.5-fold (0.19 log units), on the high side; the measured number falls inside the stated range.
By their numbers in this assay, from the lowest: compound 3; then compound 2; then compound 1.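

In this assay, among the compounds shown here, the change from 4-ethylphenyl to 4-isopropylphenyl gives a 2.1-fold lower number from compound 2 to compound 3 (0.33 log units; beyond the scatter) and so provides the first single-place step in this set. It shows that this saturated chain carbon accepts an added methyl, with a modest move towards a stronger inhibitor. No measured evidence explains this step. This one step cannot show whether the trend continues with a third methyl, as in tert-butyl, or with a cyclopropyl or a longer chain such as n-propyl. As far as these compounds go, a polar group at this place, such as an amine or a carboxylic acid, also remains open.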